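This account rests on a few compounds, and the source may have more. Where it says the series, first, only, none or still open, it means among the compounds named here.

Measured in a functional assay on NCI-H1299 cells (Homo sapiens) for inhibition, read by CCK-8 assay, with a stated time of 72 h, tested at 10 uM; on this read-out higher numbers stand for more inhibition of growth at the one concentration tested and lower numbers for less inhibition of growth:
compound 1 `CN(C)C(=O)c1cc2cnc(Nc3ccc(NC(=O)C4(C(=O)Nc5ccc(Cl)cc5)CC4)cc3)nc2n1C1CCCC1`: 88.6%
compound 2 `CN(C)C(=O)c1cc2cnc(Nc3ccc(NC(=O)C4(C(=O)Nc5cccc(Cl)c5)CC4)cc3)nc2n1C1CCCC1`: 84.1%

Going by the values given here, compound 2 stands within the scatter of compound 1, the only other compound measured here. Among the compounds with values here, the single measured step is a number 4.5 percentage points lower from compound 1 to compound 2 (within the scatter), with 3-chlorophenyl in place of 4-chlorophenyl on an amide-type nitrogen. The next compound, compound 3 `CN(C)C(=O)c1cc2cnc(Nc3ccc(NC(=O)C4(C(=O)Nc5ccc(Cl)c(C(F)(F)F)c5)CC4)cc3)nc2n1C1CCCC1`, changes the same place: 4-chloro-3-(trifluoromethyl)phenyl in place of 3-chlorophenyl on an amide-type nitrogen. In words, 4-chloro-3-(trifluoromethyl)phenyl stands in place of 3-chlorophenyl on an amide-type nitrogen. Within the data shown here, no measured compound carries a trifluoromethyl group, so the data bear on this change only indirectly. Among the measured compounds shown here, the one relevant step, a number 4.5 percentage points lower from compound 1 to compound 2 (within the scatter), gives no reason to expect a shift beyond the scatter in this assay, and none is expected. The expected step is a number 2.9 percentage points higher from compound 2 to compound 3 (within the scatter). For compound 3 the estimated value is 87%, with an expected range of 74% to 97%.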

Compound 3, percent growth inhibition at one concentration: 90.4%
Compound 3: the middle estimate sits 3.4 percentage points below what was measured; measured number inside the range.
By their numbers in this assay, from the lowest: compounds 2, 1 and 3 (each within the scatter of the next).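

In this assay the earlier pair only moved the chlorine around the phenyl ring, whereas this result shows that the amide-type nitrogen also carries a group of 11 heavy atoms in place of 7, with a number 6.3 percentage points higher from compound 2 to compound 3 (within the scatter) on that exchange. Trifluoromethyl in place of hydrogen on an aromatic carbon of the 4-chlorophenyl group gives a number 1.8 percentage points higher from compound 1 to compound 3 (within the scatter), so this addition leaves the read-out within the scatter. Nothing measured here offers an explanation for these results.

All three compounds were read at one concentration and all carry a chlorophenyl ring, so the compounds shown do not reveal what change at this position would take the read-out beyond the scatter. From the compounds shown here alone, it remains open whether a carboxylic acid or an amine on this ring, or a pyridine ring in its place, would do so.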